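Cytotoxicity notes on compounds 1 to 4

The source may hold more compounds than are shown below. What is called first, only, known or untested is meant among the compounds shown, and "the series" means these compounds.

Measured so far:
Compound 1 `O=[N+]([O-])c1ccc(NC(=S)N2CCN(S(=O)(=O)c3sccc3-c3ccccc3Oc3ccc(O)c(O)c3)CC2)cc1`: > 20000 nM
Compound 2 `Nc1ccc(Oc2ccccc2-c2ccc(S(=O)(=O)NCCNC(=O)Nc3ccc(Cl)cc3)s2)cc1`: > 20000 nM
Compound 3 `O=S(=O)(NCCNC(=S)Nc1ccc(Cl)cc1)c1ccc(-c2ccccc2OCc2ccccc2)s1`: 12100 nM

In an ADME assay on HEK-293T cells (Homo sapiens) for cytotoxicity, read by CCK-8 assay, with a stated time of 48 h (a lower number here means a stronger inhibitor, a higher number a weaker inhibitor), compound 1 reaches only the limit of the assay, > 20000 nM. Compound 2 likewise reaches only the limit, > 20000 nM. Within the data shown here, compound 3 is the one compound with an actual number, 12100 nM. The other two values sit at the limit of > 20000 nM in this assay, at which 2 of the 3 values shown sit. Among the measured compounds shown here, no pair of measured compounds differs in a single place, so no measured step is available.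

Compound 4 `O=[N+]([O-])c1cccc(NC(=S)NCCNS(=O)(=O)c2ccc(-c3ccccc3OCc3ccccc3)s2)c1` differs from compound 3 by 3-nitrophenyl in place of 4-chlorophenyl on an amide-type nitrogen. For the measured compounds named here, with no measured step to lean on, the change is expected to move this assay little, if at all beyond the usual scatter. Compound 4 is accordingly estimated at 15000 nM, within 6000 nM to 40000 nM. A reading at the limit only is also plausible for compound 4. The expected step of a 1.2-fold higher number from compound 3 to compound 4 (0.09 log units; within the scatter) is therefore essentially none.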

Compound 4, half-maximal inhibitory concentration: 18300 nM
Beside the measured number, compound 4's estimate is 1.2-fold (0.09 log units) below it; the range from low to high includes it.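

The only step shown falls on the amide-type nitrogen whose other neighbour is the thiocarbonyl carbon: in this assay, 3-nitrophenyl in place of 4-chlorophenyl gives a 1.5-fold higher number from compound 3 to compound 4 (0.18 log units; within the scatter). Among these compounds, at this position, then, the exchange of these two phenyl groups leaves the reading within the scatter, which no earlier pair could show. Much of the series gives no number to compare: the limit of > 20000 nM in this assay, at which 2 of the 4 values shown sit.

Going by these compounds, whether a carboxylic acid or a simple alkyl chain in place of this phenyl group would also leave the reading unmoved stays open. One step says nothing about other places on the shared core.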